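A Hydroxyphenyl Replaces a Dichlorophenyl on the Shared Core

A few compounds are considered here, and "the series" means these few. Any claim that something is new, unique, unknown or untested is made for them only; others in the source may bear on it.

Compound 1 `Cn1cnc2c(N3CCCCC3)nc(-c3ccccc3O)nc21`: 30.2%
Compound 2 `CN1CCN(c2nc(-c3cccc(O)c3)nc3c2ncn3C)CC1`: 47.8%
Compound 3 `Cn1cnc2c(N3CCCCC3)nc(-c3cc(Cl)ccc3Cl)nc21`: 31%

In an assay on cells for displacement of a labelled ligand from adenosine receptor A2b (Homo sapiens), read by scintillation counting and radioligand binding, with a stated time of 30 min, tested at 10 uM (a higher number here means more inhibition at the concentration tested (going by the name of the read-out), a lower number less inhibition), compound 3 gives 31%, second highest of the three numbers; compound 1 gives 30.2%, within the scatter of compound 3, while compound 2 gives 47.8%, beyond it. Compound 4 `Cn1cnc2c(N3CCCCC3)nc(-c3cccc(O)c3)nc21` has not yet been measured. It differs from compound 3 in one place: 3-hydroxyphenyl in place of 2,5-dichlorophenyl on an aromatic carbon. Within the data shown here, the only measured step that changes this same group, a number 0.8 percentage points higher from compound 1 to compound 3 (within the scatter), was within the scatter. Among the measured compounds shown here, compound 2 also carries 3-hydroxyphenyl, but its amine differs, so no single step separates it from compound 4. A modest rise is therefore expected, a number 7 percentage points higher from compound 3 to compound 4 (within the scatter). Compound 4 is estimated at 38%, between 22% and 55%.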

Compound 4, a percentage reported as inhibition, at one concentration (the size of the read-out at that concentration, not a potency): 29.3%
Estimate against measurement, compound 4: 8.7 percentage points above; low and high end bracket the measured number.
By their numbers in this assay, from the lowest: compounds 4, 1 and 3 (each within the scatter of the next); then compound 2.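

On the shared core carrying piperidin-1-yl, the aromatic group changes little: 3-hydroxyphenyl in place of 2,5-dichlorophenyl gives a number 1.7 percentage points lower from compound 3 to compound 4 (within the scatter), and 3-hydroxyphenyl in place of 2-hydroxyphenyl gives a number 0.9 percentage points lower from compound 1 to compound 4 (within the scatter). So these three groups cannot be told apart in this measurement. The amine can be: with 3-hydroxyphenyl kept, piperidin-1-yl in place of 4-methylpiperazin-1-yl gives a number 18.5 percentage points lower from compound 2 to compound 4 (beyond the scatter).

Nothing available explains these numbers. As far as these compounds go, whether a morpholine in place of piperidin-1-yl would keep the higher number stays open, as does whether the aromatic group matters alongside 4-methylpiperazin-1-yl.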